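Chloro for Fluoro on the Methoxy-Bearing Core

A few compounds are considered here, and "the series" means these few. Any claim that something is new, unique, unknown or untested is made for them only; others in the source may bear on it.

Of the compounds shown here, three sharing one core have been measured. Compound 1 `Cc1ccc(S(=O)(=O)c2nc3ccccc3nc2Nc2ccc(F)cc2)cc1` gives 8950 nM in a functional assay on KB cells (Homo sapiens) for cytotoxicity, read by MTT assay, with a stated time of 72 h; a higher number here means a weaker inhibitor, a lower number a stronger inhibitor. Compound 2 `Cc1ccc(S(=O)(=O)c2nc3ccccc3nc2Nc2ccc(Cl)cc2)cc1` carries chloro in place of fluoro on an aromatic carbon and gives 13800 nM in this assay. Compound 3 `COc1ccc(S(=O)(=O)c2nc3ccccc3nc2Nc2ccc(F)cc2)cc1` differs from compound 1 by methoxy in place of methyl on an aromatic carbon; in this assay compound 3 gives 2590 nM, the lowest of the three numbers, reached by a 3.5-fold lower number from compound 1 to compound 3 (0.54 log units; beyond the scatter). Compound 4 `COc1ccc(S(=O)(=O)c2nc3ccccc3nc2Nc2ccc(Cl)cc2)cc1` has not yet been measured; it differs from compound 3 by chloro in place of fluoro on an aromatic carbon, the same change as that from compound 1 to compound 2, now made on the core of compound 3. Because the earlier step was a 1.5-fold higher number from compound 1 to compound 2 (0.19 log units; within the scatter), a step of similar size is expected here, a 1.5-fold higher number from compound 3 to compound 4 (0.18 log units; within the scatter). Compound 4 is therefore estimated at 3900 nM in this assay, likely between 1800 nM and 9000 nM.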

Compound 4, half-maximal inhibitory concentration: 49800 nM
For compound 4 the middle estimate is 13-fold (1.11 log units) below the measured one, outside the stated range (above it).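

In this assay, chloro in place of fluoro did not carry over unchanged from one core to the other, for the new step, a 19-fold higher number from compound 3 to compound 4 (1.28 log units; beyond the scatter), stands well apart from the earlier one: the same change on two cores in this assay, a 1.5-fold higher number (0.19 log units; within the scatter) from compound 1 to compound 2 and a 19-fold higher number (1.28 log units; beyond the scatter) from compound 3 to compound 4, 12-fold (1.10 log units) apart, beyond the scatter of two such steps. Methoxy in place of methyl likewise changes direction with the halogen present, the new step being a 3.6-fold higher number from compound 2 to compound 4 (0.56 log units; beyond the scatter): the same change on two cores in this assay, a 3.5-fold lower number (0.54 log units; beyond the scatter) from compound 1 to compound 3 and a 3.6-fold higher number (0.56 log units; beyond the scatter) from compound 2 to compound 4, 12-fold (1.10 log units) apart, beyond the scatter of two such steps. Across these four compounds the two changes therefore do not act independently, but the numbers do not show why, nor whether this holds beyond these compounds.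

The compounds shown leave open how bromo in place of chloro would read on either core. Also open, from the compounds shown here alone, is whether ethoxy or a dimethylamino group in place of methoxy would show the same dependence on the halogen.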